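Adding a chloro group to a well-tolerated compound

The source may hold more compounds than are shown below. What is called first, only, known or untested is meant among the compounds shown, and "the series" means these compounds.

In an ADME assay on MDBK cells (Bos taurus) for cytotoxicity, read by MTT assay, with a stated time of 72 h (a higher number here means that more compound is tolerated, a lower number that less compound is tolerated), compound 2 `Cc1ccc(-c2nn(-c3ccccc3)cc2CNc2ccccc2)cc1` gives > 100000 nM as its reading, which is a limit of the assay and not a number. Compound 3 `Cc1ccc(-c2nn(-c3ccccc3)cc2CNc2ccc(Cl)cc2)cc1` differs from it in one place chloro in place of hydrogen on an aromatic carbon with chloro in place of hydrogen on an aromatic carbon, para to a large group. Compound 1 `FC(F)(F)c1ccc(-c2nn(-c3ccccc3)cc2CNc2ccc(Cl)cc2)cc1` also carries the (4-chlorophenyl)amino group and gives 44000 nM in this assay as a true number, so a downward step is expected here. The expected step of an at least 1.6-fold lower number from compound 2 to compound 3 (0.22 log units; that floor lies within the scatter) is a modest fall in the concentration tolerated. Compound 3 is expected at 60000 nM with an estimated range of 25000 nM to 100000 nM in this assay.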

Compound 3, half-maximal cytotoxic concentration: > 100000 nM
Compound 3: only a limit was reported; the forecaster's own chance of this, stated with the estimate: 30%; at least 1.6-fold (0.22 log units) between middle value and limit.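

The step between compound 2 and compound 3 cannot be read, because both readings are limits of the assay: the limit of > 100000 nM in this assay, at which 2 of the 3 values shown sit.

What the new compound does show comes from the other end of the molecule. With the (4-chlorophenyl)amino group kept, methyl in place of trifluoromethyl gives an at least 2.2-fold higher number from compound 1 to compound 3 (0.35 log units; beyond the scatter) in this assay, so the chloro group alone does not bring the reading down to a true number.

Whether chloro has any effect when trifluoromethyl is present stays open, since the compounds shown include no anilino partner carrying trifluoromethyl. On these data alone, it is also open whether a methoxy group or an amine at this position would give a true number.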